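A few compounds are considered here, and "the series" means these few. Any claim that something is new, unique, unknown or untested is made for them only; others in the source may bear on it.

Measured so far in an ADME assay on the whole organism (strain FVB) for pharmacokinetics, with Mus musculus as the target, read by LC-MS, at a dose of 30 mg/kg by the oral route; on this read-out higher numbers stand for higher exposure at the dose given and lower numbers for lower exposure:
- compound 1 `c1cc([C@H]2CC[C@]3(CC2)OOC2(O3)C3CC4CC(C3)CC2C4)ccc1OCCOC1CCNCC1`: 633 nM
- compound 2 `CC(C)(N)CCOc1ccc([C@H]2CC[C@]3(CC2)OOC2(O3)C3CC4CC(C3)CC2C4)cc1`: 1050 nM
- compound 3 `CC(C)(CN)Oc1ccc([C@H]2CC[C@]3(CC2)OOC2(O3)C3CC4CC(C3)CC2C4)cc1`: 529 nM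

Compound 3, at 529 nM, lies within the scatter of both other compounds, so no order can be drawn among them. Compound 4 `CC1(C)CC(O)(COc2ccc([C@H]3CC[C@]4(CC3)OOC3(O4)C4CC5CC(C4)CC3C5)cc2)CC(C)(C)N1` is the next to be measured, and its change is (4-hydroxy-2,2,6,6-tetramethylpiperidin-4-yl)methyl in place of 1-(aminomethyl)-1-methylethyl on an oxygen on an aromatic ring. The nearest evidence comes from other exchanges of the group on the same oxygen or its chain: a 1.2-fold lower number from compound 1 to compound 3 (0.08 log units; within the scatter), a 2.0-fold lower number from compound 2 to compound 3 (0.30 log units; within the scatter) and a 1.7-fold higher number from compound 1 to compound 2 (0.22 log units; within the scatter). Going by the values given here, none of these goes beyond the scatter, although only three compounds support this. No step beyond the scatter is therefore expected in this assay, and no direction is favoured. The expected step is a 1.1-fold higher number from compound 3 to compound 4 (0.04 log units; within the scatter). For compound 4 the estimated value is 580 nM, with an expected range of 200 nM to 1500 nM.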

Compound 4, maximal plasma concentration: 1000 nM
Compound 4: the middle estimate sits 1.7-fold (0.24 log units) below what was measured, and the stated range covers the measured number.
By their numbers in this assay, from the lowest: compounds 3, 1, 4 and 2 (each within the scatter of the next).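

In this assay, the oxygen on the aromatic ring carries the larger (4-hydroxy-2,2,6,6-tetramethylpiperidin-4-yl)methyl group, with its six-membered non-aromatic ring, and the step stays within the scatter: a 1.9-fold higher number from compound 3 to compound 4 (0.28 log units; within the scatter). The other two steps, a 1.1-fold lower number from compound 2 to compound 4 (0.02 log units; within the scatter) and a 1.6-fold higher number from compound 1 to compound 4 (0.20 log units; within the scatter), are also within the scatter, so this bulkier ring-bearing group sets no order among the four compounds. No measurement at hand bears on why these steps are this small.

All four compounds carry an amine on this chain. From the compounds shown here alone, whether a carboxylic acid or a plain alkyl ether on the same oxygen would stay within the scatter remains open.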